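Furan-2-yl in Place of Phenyl: Expected Cytotoxicity

The compounds below may be only part of what the source reports. "The series", "measured", "known", "first", "only" and "open" are said of these compounds alone.

Compound 1: `Oc1cccc(-c2cc(-c3ccc(Cl)cc3)nc(-c3ccco3)c2)c1`, 8190 nM
Compound 2: `Oc1ccc(-c2cc(-c3ccccc3)nc(-c3ccc(Cl)cc3)c2)cc1`, 4810 nM

In an ADME assay on HEK293 cells (Homo sapiens) for cytotoxicity, read by CCK-8 assay and cell counting, with a stated time of 2 days (a higher number here means a weaker inhibitor, a lower number a stronger inhibitor), compound 2 gives 4810 nM, the lowest of the two numbers. Compound 1 gives 8190 nM, and the gap between the two lies within the scatter, so nothing can be said about which is the weaker inhibitor. Compound 3 (`Oc1ccc(-c2cc(-c3ccc(Cl)cc3)nc(-c3ccco3)c2)cc1`) has not yet been measured. The change from compound 2 to compound 3 is furan-2-yl in place of phenyl on an aromatic carbon. Among the compounds with values here, with no comparable step among the measured compounds, no step beyond the scatter is expected in this assay. Compound 3 is expected to give about 6000 nM, between 2500 nM and 15000 nM, a step of a 1.2-fold higher number from compound 2 to compound 3 (0.10 log units; within the scatter).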

Compound 3, half-maximal inhibitory concentration: 5720 nM
For compound 3 the middle estimate is 1.0-fold (0.02 log units) above the measured one; measured number inside the range.
By their numbers in this assay, from the lowest: compounds 2, 3 and 1 (each within the scatter of the next).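

At this position, next to the ring nitrogen, furan-2-yl in place of phenyl gives a 1.2-fold higher number from compound 2 to compound 3 (0.08 log units; within the scatter) in this assay, so exchanging the six-membered carbon ring for a five-membered ring with one hetero atom leaves no readable step here. Compound 3 also allows a second comparison: 4-hydroxyphenyl in place of 3-hydroxyphenyl gives a 1.4-fold lower number from compound 1 to compound 3 (0.16 log units; within the scatter) and likewise leaves no readable step. As far as these compounds go, whether an amine or a carboxylic acid at the furan-2-yl position would give a step beyond the scatter remains open. Nothing measured here bears on the reason for these results.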